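From 2-hydroxyethyl to 2-methoxyethyl in compound 1

The source may hold more compounds than are shown below. What is called first, only, known or untested is meant among the compounds shown, and "the series" means these compounds.

Measured so far in a physicochemical assay for solubility, using the shake flask method, in phosphate buffer, with a stated time of 90 min, at pH 6.8 (a lower number here means a less soluble compound, a higher number a more soluble compound), are these compounds:
- compound 1 `COc1cc(/C=C/C(=O)/C=C(/C=C/c2ccc(O)c(OC)c2)NCCO)ccc1O` gives 8140 nM
- compound 2 `COc1cc(/C=C/C2=CC(=O)CC(c3ccc(O)c(OC)c3)N2CCCO)ccc1O` gives 58900 nM

Compound 1 holds the lower of the two numbers, and its gap to compound 2 lies beyond the scatter. Compound 3 `COCCNC(=C\C(=O)/C=C/c1ccc(O)c(OC)c1)/C=C/c1ccc(O)c(OC)c1` carries 2-methoxyethyl where compound 1 carries 2-hydroxyethyl, with methyl in place of hydrogen on an oxygen on a saturated carbon. Among the measured compounds shown here, no measured pair shows this change on its own, so the expectation is tentative: a small downward step in this assay, possibly none beyond the scatter. The expected step is modest (a 1.5-fold lower number from compound 1 to compound 3 (0.17 log units; within the scatter)). Compound 3 is estimated at 5500 nM (expected range 1800 nM to 16000 nM).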

Compound 3, solubility: 16700 nM
Estimate against measurement, compound 3: 3.0-fold (0.48 log units) below; measured number outside the range, above it.
By their numbers in this assay, from the lowest: compound 1; then compound 3; then compound 2.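

In this assay, among the compounds shown here, replacing 2-hydroxyethyl with 2-methoxyethyl gives a 2.1-fold higher number from compound 1 to compound 3 (0.31 log units; beyond the scatter), the first step with a single point of difference. At this position, methyl can replace the hydrogen on the oxygen without lowering the number; the step runs upward, beyond the scatter. Nothing available explains the direction of this step. Still open, from the compounds shown here alone, is whether a terminal amine, a carboxylic acid or a longer chain ending in methoxy would move the number further. Also open, going by these compounds, is whether the same change gives a similar step on the core of compound 2.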